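A few compounds are considered here, and "the series" means these few. Any claim that something is new, unique, unknown or untested is made for them only; others in the source may bear on it.

Compound 3 `O=C(CCc1ccc(-c2ccccc2)cc1)c1ncc(C(=O)C(F)(F)F)o1` is the strongest of the three measured compounds in an assay for inhibition of Fatty-acid amide hydrolase 1 (Rattus norvegicus); a lower number here means a stronger inhibitor, a higher number a weaker inhibitor: compound 3 gives 8 nM. Compound 2 `O=C(O)c1ccc(-c2cnc(C(=O)CCc3ccc(-c4ccccc4)cc3)o2)nc1` gives 14 nM, and compound 1 `O=C(O)c1cc(-c2cnc(C(=O)CCc3ccc(-c4ccccc4)cc3)o2)ccn1` gives 50 nM. One gap is clear, a 6.3-fold lower number from compound 1 to compound 3 (0.80 log units; beyond the scatter); the other lies within the scatter, a 1.8-fold lower number from compound 2 to compound 3 (0.24 log units; within the scatter).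

Compound 4 `NC(=O)c1cccc(-c2cnc(C(=O)CCc3ccc(-c4ccccc4)cc3)o2)n1` differs from compound 3 in one place: 6-carbamoylpyridin-2-yl in place of (trifluoromethyl)carbonyl on an aromatic carbon. For the measured compounds named here, the steps that bear on this change are the two that swap a carboxypyridyl group for the trifluoromethyl ketone, namely a 6.3-fold lower number from compound 1 to compound 3 (0.80 log units; beyond the scatter) and a 1.8-fold lower number from compound 2 to compound 3 (0.24 log units; within the scatter); both run toward compound 3, so going back to an aromatic group points toward a higher number. The new group is a carboxamide rather than a carboxylic acid, and its attachment on the pyridine is different from either measured case, so the size is uncertain. A modest weakening is expected, a 3.8-fold higher number from compound 3 to compound 4 (0.57 log units; beyond the scatter), giving for compound 4 an estimated value of 30 nM with a range from 8 nM to 120 nM.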

Compound 4, inhibition constant: 1.2 nM
Estimate against measurement, compound 4: 25-fold (1.40 log units) above, and the stated range ends above it.
By their numbers in this assay, from the lowest: compound 4; then compounds 3 and 2 (each within the scatter of the next); then compound 1.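

At this position, on an aromatic carbon next to the ring oxygen, an aromatic group can give a stronger inhibitor than the trifluoromethyl ketone in this assay, with 6-carbamoylpyridin-2-yl giving a 6.7-fold lower number from compound 3 to compound 4 (0.82 log units; beyond the scatter), a step beyond the scatter that neither carboxypyridyl group had shown. The same group also separates clearly from both carboxypyridyl groups, with a 12-fold lower number from compound 2 to compound 4 (1.07 log units; beyond the scatter) and a 42-fold lower number from compound 1 to compound 4 (1.62 log units; beyond the scatter), so the choice of substituted pyridine at this one position matters a great deal. Nothing measured here accounts for these steps.

The carboxamide and its place on the pyridine both differ from compound 1 and compound 2, so the compounds shown do not separate the two. On these data alone, how a 6-carboxypyridin-2-yl group or a 6-cyanopyridin-2-yl group would compare with 6-carbamoylpyridin-2-yl remains open.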